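The compounds below may be only part of what the source reports. "The series", "measured", "known", "first", "only" and "open" are said of these compounds alone.

Measured compounds:

Compound 1, `COc1c(OCCCCN2CCN(C)CC2)cc(O)c2c(=O)cc(-c3ccc(Br)cc3)oc12`: 3210 nM
Compound 2, `CN1CCN(CCCOc2c(OCc3ccccc3)cc(O)c3c(=O)cc(-c4ccccc4)oc23)CC1`: 1020 nM

Both were tested in a functional assay on MCF7 cells (Homo sapiens) for cytotoxicity, read by MTT assay, with a stated time of 72 h; a lower number here means a stronger inhibitor, a higher number a weaker inhibitor. Compound 2 stands at the lower of the two numbers, and compound 1, which differs from it in more than one place, sits above it by a gap beyond the usual scatter. Among the measured compounds shown here, no pair of measured compounds differs in a single place, so no measured step can be read off.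

Compound 3, `O=c1cc(-c2ccccc2)oc2c(OCCCCN3CCCC3)c(OCc3ccccc3)cc(O)c12`, is not yet measured. It differs from compound 2 by one change: (pyrrolidin-1-yl)methyl in place of 4-methylpiperazin-1-yl on a saturated chain carbon, three bonds along the chain from an oxygen on an aromatic ring. For the measured compounds named here, nothing among the measured compounds shows what such a change does in this assay. The expectation is therefore a small step, with no direction favoured and most likely within the scatter of the assay, as a 1.2-fold higher number from compound 2 to compound 3 (0.07 log units; within the scatter). For compound 3 the estimated result in this assay is 1200 nM, with a range from 400 nM to 3600 nM.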

Compound 3, half-maximal inhibitory concentration: 1890 nM
Compound 3: middle estimate off by 1.6-fold (0.20 log units), on the low side; measured number inside the range.
By their numbers in this assay, from the lowest: compounds 2, 3 and 1 (each within the scatter of the next, the first and the last beyond it).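

In this assay, among the compounds shown here, the move from the 3-(4-methylpiperazin-1-yl)propyl arm to the 4-(pyrrolidin-1-yl)butyl arm gives a 1.9-fold higher number from compound 2 to compound 3 (0.27 log units; within the scatter) and provides the first measured single change in this set. At this place on the chain, the two arms cannot be told apart by this read-out, so this amine ring and chain can be exchanged here without a clear change in the number. No measurement shown here bears on why the two arms fall so close together.

On these data alone, because the ring and the chain length change together in this step, their separate contributions remain unknown. A 3-(pyrrolidin-1-yl)propyl arm would help to separate them, and a morpholin-4-yl ring at the end of the chain would test a different ring at this place.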